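Lengthening the Alkenyl Chain of Compound 3

The source may hold more compounds than are shown below. What is called first, only, known or untested is meant among the compounds shown, and "the series" means these compounds.

- compound 1 `C=C(C)C(=O)Nc1cc2c(N3CCc4ccccc43)ncnc2cc1OC`: 11100 nM
- compound 2 `CCC/C=C/C(=O)Nc1cc2c(N3CCc4ccccc43)ncnc2cc1OC`: 3160 nM
- compound 3 `C/C=C/C(=O)Nc1cc2c(N3CCCc4ccccc43)ncnc2cc1OC`: 12700 nM

In a functional assay on MCF7 cells (Homo sapiens) for antiproliferative activity, read by MTT assay, with a stated time of 72 h (on this read-out higher numbers stand for weaker inhibition and lower numbers for stronger inhibition), compound 3 gives 12700 nM, the highest of the three numbers but within the scatter of compound 1, while compound 2 shows a clearly lower number. Compound 4 `CCC/C=C/C(=O)Nc1cc2c(N3CCCc4ccccc43)ncnc2cc1OC` differs from compound 3 by ethyl in place of hydrogen on a saturated chain carbon bound to a double-bonded chain carbon, which turns (prop-1-en-1-yl)carbonyl into (pent-1-en-1-yl)carbonyl. Going by the values given here, one measured step bears on this: a 3.5-fold lower number from compound 1 to compound 2 (0.55 log units; beyond the scatter). That step also arrives at pent-1-en-1-yl, but it starts from a different group on a different core, so it is only indirect evidence. A lower number of similar or slightly smaller size is therefore expected in this assay. The expected change is a 2.8-fold lower number from compound 3 to compound 4 (0.45 log units; beyond the scatter). For compound 4 the estimated value is 4500 nM, with an expected range of 1800 nM to 11000 nM.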

Compound 4, half-maximal inhibitory concentration: 1210 nM
Compound 4: the middle estimate sits 3.7-fold (0.57 log units) above what was measured; measured number outside the range, below it.
By their numbers in this assay, from the lowest: compound 4; then compound 2; then compounds 1 and 3 (each within the scatter of the next).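

In this assay, ethyl in place of hydrogen on the saturated chain carbon gives a 10-fold lower number from compound 3 to compound 4 (1.02 log units; beyond the scatter), a large step that reads the change from prop-1-en-1-yl to pent-1-en-1-yl directly. With pent-1-en-1-yl held constant, 1,2,3,4-tetrahydroquinolin-1-yl in place of 2,3-dihydro-1H-indol-1-yl gives a 2.6-fold lower number from compound 2 to compound 4 (0.42 log units; beyond the scatter), so this group on the aromatic carbon also moves the number. Nothing available here accounts for either step. The compounds leave open whether a chain longer than pent-1-en-1-yl, or one carrying a dimethylamine, would lower the number further.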